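Adding a Nitro Group to a Short-Lived Ester

This account rests on a few compounds, and the source may have more. Where it says the series, first, only, none or still open, it means among the compounds named here.

Compound 1 `CC(=O)Oc1ccccc1C(=O)O[C@H]1CO[C@H]2[C@@H]1OC[C@H]2OC(C)=O` is a diester built on a shared bicyclic core; in an ADME assay on a cell-free system (plasma, Homo sapiens) for metabolic stability, with Plasma (Rattus norvegicus) as the target, read by HPLC, at pH 7.4 (on this read-out higher numbers stand for a longer-lived compound and lower numbers for a shorter-lived compound), compound 1 gives 0.0608 h. Compound 2 `CC(=O)Oc1ccccc1C(=O)O[C@H]1CO[C@H]2[C@@H]1OC[C@H]2OC(=O)c1ccccc1` differs by a phenyl in place of methyl on a carbonyl carbon, and in this assay compound 2 gives 0.055 h. That single measured step, a 1.1-fold lower number from compound 1 to compound 2 (0.04 log units; within the scatter), left the half-life essentially unchanged. Compound 2 therefore stands alongside compound 1, the two numbers within the scatter of each other, so neither can be ranked above the other.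

Compound 3 `CC(=O)Oc1ccccc1C(=O)O[C@H]1CO[C@H]2[C@@H]1OC[C@H]2OC(=O)c1ccc([N+](=O)[O-])cc1` carries the next change: nitro in place of hydrogen on an aromatic carbon. Among the measured compounds shown here, no measured step involves a nitro, so only the unchanged result from compound 1 to compound 2 offers guidance, and it speaks for a small effect of changes at this end of the molecule. The expected step is no change at the digits printed from compound 2 to compound 3 (within the scatter), within the scatter. Compound 3 is estimated at 0.055 h, with a range from 0.028 h to 0.11 h.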

Compound 3, half-life: 0.0462 h
Beside the measured number, compound 3's estimate is 1.2-fold (0.08 log units) above it, and the stated range covers the measured number.
By their numbers in this assay, from the lowest: compounds 3, 2 and 1 (each within the scatter of the next).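

Nitro in place of hydrogen on an aromatic carbon, para to a large group, gives a 1.2-fold lower number from compound 2 to compound 3 (0.08 log units; within the scatter) in this assay, so this first substitution on the new phenyl ring does not separate the two compounds on this read-out. The full replacement, 4-nitrophenyl in place of methyl on a carbonyl carbon, gives a 1.3-fold lower number from compound 1 to compound 3 (0.12 log units; within the scatter), which shows that even this larger overall change at the same carbonyl carbon stays within the usual spread of repeated measurements. No measurement at hand offers an explanation for this result.

From the compounds shown here alone, whether an amine or a carboxylic acid on that same aromatic carbon would also leave the half-life within the scatter remains open. So does the effect of a longer chain in place of the acetyl group that all three compounds share.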